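Two changes to a shared core, and their combination

The source may hold more compounds than are shown below. What is called first, only, known or untested is meant among the compounds shown, and "the series" means these compounds.

Measured so far:
Compound 1, `COc1ccc(Nc2nc3ccccc3nc2S(=O)(=O)c2ccc(C)cc2)cc1`, gives in a functional assay on A549 cells (Homo sapiens) for cytotoxicity, read by MTT assay, with a stated time of 72 h (a higher number here means a weaker inhibitor, a lower number a stronger inhibitor), a reading of > 50000 nM, which is a limit of the assay and not a number.
Compound 2, `COc1cc(Nc2nc3ccccc3nc2S(=O)(=O)c2ccc(C)cc2)cc(OC)c1`, gives in this assay a value of 8060 nM.
Compound 3, `COc1ccc(Nc2nc3ccccc3nc2S(=O)(=O)c2ccc(F)cc2)cc1`, gives in this assay a value of 4840 nM.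

The three compounds share one core and differ in two places. From compound 1 to compound 2 the change is 3,5-dimethoxyphenyl in place of 4-methoxyphenyl on a nitrogen on an aromatic ring, and the step is an at least 6.2-fold lower number from compound 1 to compound 2 (0.79 log units; beyond the scatter). Compound 4, `COc1cc(Nc2nc3ccccc3nc2S(=O)(=O)c2ccc(F)cc2)cc(OC)c1`, has not yet been measured. It is built on the core of compound 3, which differs from the core of compound 1 by fluoro in place of methyl on an aromatic carbon, a change whose step was an at least 10-fold lower number from compound 1 to compound 3 (1.01 log units; beyond the scatter). Compound 4 differs from compound 3 by 3,5-dimethoxyphenyl in place of 4-methoxyphenyl on a nitrogen on an aromatic ring, the same change, at the same place, as that from compound 1 to compound 2.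

If the change carries over, compound 4 is expected to show a 4.8-fold lower number from compound 3 to compound 4 (0.68 log units; beyond the scatter), resting on an at least 6.2-fold lower number from compound 1 to compound 2 (0.79 log units; beyond the scatter), which is only a lower bound because compound 1 sits at the limit of > 50000 nM in this assay, at which 1 of the 3 values shown sits. Compound 4 is therefore estimated at 1000 nM in this assay, between 250 nM and 5000 nM.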

Compound 4, half-maximal inhibitory concentration: 5450 nM
The estimate for compound 4 lay 5.5-fold (0.74 log units) below the measured number; the whole stated range lies below it.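

In this assay, the change from 4-methoxyphenyl to 3,5-dimethoxyphenyl gives a 1.1-fold higher number from compound 3 to compound 4 (0.05 log units; within the scatter) on the core of compound 3, so it did not carry over in the size seen on the core of compound 1: the same change on two cores in this assay, an at least 6.2-fold lower number (0.79 log units; beyond the scatter) from compound 1 to compound 2 and a 1.1-fold higher number (0.05 log units; within the scatter) from compound 3 to compound 4, at least 6.9-fold (0.84 log units) apart, beyond the scatter of two such steps. The change from methyl to fluoro likewise gives a 1.5-fold lower number from compound 2 to compound 4 (0.17 log units; within the scatter), and across these four compounds the two changes therefore do not add up: the same change on two cores in this assay, an at least 10-fold lower number (1.01 log units; beyond the scatter) from compound 1 to compound 3 and a 1.5-fold lower number (0.17 log units; within the scatter) from compound 2 to compound 4, at least 6.9-fold (0.84 log units) apart, beyond the scatter of two such steps. The compounds do not show why the steps differ, and both comparisons rest on compound 1, whose reading is a limit and not a number: the limit of > 50000 nM in this assay, at which 1 of the 4 values shown sits.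

The compounds shown leave open how other groups in place of the fluoro, such as chloro or nitrile, would behave with each of the two aryl groups on the nitrogen. They also leave open whether an amine or a carboxylic acid in place of the methoxy groups would follow either pattern in this assay.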